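The source may report more compounds than this note shows. Statements on the series, on what has been measured and on what is new or still open speak of the compounds shown alone.

Measured so far:
compound 1 `CC(C(=O)NCc1ccc(C(F)(F)F)cc1N1CCCCCC1)c1ccc(NS(C)(=O)=O)c(F)c1`: 1.6 nM
compound 2 `CC(C(=O)NCc1ccc(C(F)(F)F)cc1N1CCCCCCC1)c1ccc(NS(C)(=O)=O)c(F)c1`: 2.8 nM
compound 3 `CC(C(=O)NCc1ccc(C(F)(F)F)cc1N1CCC(C)(C)CC1)c1ccc(NS(C)(=O)=O)c(F)c1`: 1.3 nM

All three share one core and differ only in the saturated ring that hangs from an aromatic carbon. In an assay on CHO cells for antagonist activity at transient receptor potential cation channel subfamily V member 1 (Homo sapiens), read by FLIPR (a lower number here means a stronger inhibitor, a higher number a weaker inhibitor), compound 2 gives the largest of the three numbers. Its gap to compound 1 is small: a 1.8-fold higher number from compound 1 to compound 2 (0.24 log units; within the scatter). Its gap to compound 3 is a little wider: a 2.2-fold lower number from compound 2 to compound 3 (0.33 log units; beyond the scatter). Compound 1 and compound 3 sit close together: a 1.2-fold lower number from compound 1 to compound 3 (0.09 log units; within the scatter).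

Compound 4 `CC(C(=O)NCc1ccc(C(F)(F)F)cc1N1CCC(C(F)(F)F)CC1)c1ccc(NS(C)(=O)=O)c(F)c1` has not yet been measured. It differs from compound 2 in one place: a group of 10 heavy atoms (6 carbon, 1 nitrogen, 3 fluorine; one six-membered non-aromatic ring with 1 hetero atom) in place of a group of 8 heavy atoms (7 carbon, 1 nitrogen; one eight-membered non-aromatic ring with 1 hetero atom), on an aromatic carbon. Among the compounds with values here, the one measured step that bears on this is the one from the eight-membered ring to a six-membered ring carrying two methyl groups, a 2.2-fold lower number from compound 2 to compound 3 (0.33 log units; beyond the scatter), which was modest. The new six-membered ring carries a trifluoromethyl group instead, and nothing measured here tells how that substituent behaves. A small step toward a lower number is therefore expected, close to that seen for compound 3, but with room on either side. The step from compound 2 to compound 4 is estimated as a 1.4-fold lower number from compound 2 to compound 4 (0.15 log units; within the scatter). For compound 4 the expected value in this assay is 2 nM, within a range from 0.8 nM to 5 nM.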

Compound 4, inhibition constant: 0.4 nM
For compound 4 the middle estimate is 5.0-fold (0.70 log units) above the measured one, outside the stated range (below it).
By their numbers in this assay, from the lowest: compound 4; then compounds 3, 1 and 2 (each within the scatter of the next, the first and the last beyond it).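

In this assay, within the data shown here, the ring on this aromatic carbon matters more than the earlier compounds suggested: 4-(trifluoromethyl)piperidin-1-yl stands clear of all three earlier rings, with a 7.0-fold lower number from compound 2 to compound 4 (0.85 log units; beyond the scatter), a 4.0-fold lower number from compound 1 to compound 4 (0.60 log units; beyond the scatter) and a 3.3-fold lower number from compound 3 to compound 4 (0.51 log units; beyond the scatter). The last of these steps keeps the six-membered ring and exchanges only the two methyl groups for one trifluoromethyl group, so ring size alone does not set the number here. No measurement shown explains why this ring gives the lowest number.

On these data alone, it remains open whether a smaller group on the same ring, as in 4-methylpiperidin-1-yl or 4-fluoropiperidin-1-yl, would give a similar number. Also open, as far as these compounds go, is whether a trifluoromethyl group would give a similar step on a seven-membered or eight-membered ring.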